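The compounds below may be only part of what the source reports. "The series", "measured", "known", "first", "only" and "open" are said of these compounds alone.

Working notes on the series in an ADME assay on BJ cells (Homo sapiens) for cytotoxicity, with a stated time of 72 h; a lower number here means that less compound is needed, a higher number that more compound is needed for the effect. Three compounds have been run, and none gave a number. Compound 1 `O=C(Nc1cc(-c2nc3ccccc3s2)ccc1Cl)c1cc([N+](=O)[O-])ccc1Cl` reaches only the limit of the assay, recorded as > 25000 nM. Compound 2 `O=C(Nc1ccc(Cl)c(-c2nc3ccccc3s2)c1)c1cc([N+](=O)[O-])ccc1Cl` likewise stops at a limit, > 25000 nM. Compound 3 `O=C(Nc1ccc(-c2nc3ccccc3s2)cc1)c1cc([N+](=O)[O-])ccc1Cl` also returns a limit, > 27000 nM. Compounds 1 and 2 share (the limit of > 25000 nM in this assay, at which 2 of the 3 values shown sit). Compound 3 alone sits at the limit of > 27000 nM in this assay, at which 1 of the 3 values shown sits. So compound 3 stands where the whole set stands: no cytotoxicity measurable within the range tested, and no ordering among the three can be read from limits alone. Within the data shown here, no step between two measured compounds is available, and nothing in the set points to any one part of the core as the source of a difference in this assay.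

The next compound, compound 4 `O=C(Nc1ccc(Cl)cc1)c1cc([N+](=O)[O-])ccc1Cl`, strips the series down. The change is chloro in place of 1,3-benzothiazol-2-yl on an aromatic carbon. Among the measured compounds shown here, since the only evidence is that compounds 1, 2 and 3 all sit at limits, the expectation for this step is none beyond the scatter, a step that the limit leaves unreadable from compound 3 to compound 4 from compound 3 to compound 4, with the real outcome most likely again a limit rather than a number. Compound 4 is therefore estimated at 30000 nM in this assay, within a range of 10000 nM to 100000 nM.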

Compound 4, half-maximal effective concentration: > 27000 nM
Compound 4 gave a limit, no number; the forecaster's own chance of this, stated with the estimate: 85%; the middle value is on the limit's open side.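

In this assay compound 4 returns only a limit, > 27000 nM. Compounds 2 and 3 also sit at limits, so neither step to compound 4 can be read. The compounds shown leave open whether removing or replacing 1,3-benzothiazol-2-yl changes the result in this assay, since none of them gives an actual number.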